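Adding methoxy to compound 1: what to expect

A few compounds are considered here, and "the series" means these few. Any claim that something is new, unique, unknown or untested is made for them only; others in the source may bear on it.

- Compound 1 `FC(F)(F)c1ccc(/C=C\c2cc3ccccc3nc2Cl)cc1` gives 5360 nM
- Compound 2 `Fc1ccc(/C=C\c2cc3ccccc3nc2Cl)cc1` gives 24000 nM
- Compound 3 `FC(F)(F)c1ccc(/C=C\c2cc3ccc(Cl)cc3nc2Cl)cc1` gives 13600 nM

These values come from a functional assay on MDA-MB-231 cells (Homo sapiens) for antiproliferative activity, read by sulforhodamine B assay, with a stated time of 72 h (a higher number here means a weaker inhibitor, a lower number a stronger inhibitor), and compound 1 holds the lowest number of the three, with both of its steps to the others beyond the scatter. Compound 4 `COc1ccc2nc(Cl)c(/C=C\c3ccc(C(F)(F)F)cc3)cc2c1` differs from compound 1 in one place (methoxy in place of hydrogen on an aromatic carbon) and carries methoxy in place of hydrogen on an aromatic carbon. The closest measured guide is a 2.5-fold higher number from compound 1 to compound 3 (0.40 log units; beyond the scatter) where chloro replaces hydrogen on an aromatic carbon of the core. The other measured step, a 4.5-fold higher number from compound 1 to compound 2 (0.65 log units; beyond the scatter) changes the trifluoromethyl group instead and so bears on this question only loosely. Going by the values given here, no methoxy compound has been measured yet, which makes chloro a rough stand-in. A similar modest weakening is therefore expected, and the estimated change is a 1.7-fold higher number from compound 1 to compound 4 (0.23 log units; within the scatter) in this assay with real doubt about its size. Compound 4 is expected to give 9000 nM with 3500 nM to 22000 nM as the estimated range.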

Compound 4, half-maximal inhibitory concentration: 22800 nM
For compound 4 the middle estimate is 2.5-fold (0.40 log units) below the measured one, outside the stated range (above it).
By their numbers in this assay, from the lowest: compound 1; then compounds 3, 4 and 2 (each within the scatter of the next).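

In this assay, going by these compounds alone, placing methoxy on this carbon of the shared core gives a 4.3-fold higher number from compound 1 to compound 4 (0.63 log units; beyond the scatter), the first direct reading for a methoxy group rather than a chloro stand-in. Within the data shown here, the change is only one small group on an aromatic carbon, meta to a fused ring and para to a fused ring, yet it costs clearly more than the estimate allowed, so this carbon does not accept methoxy without a loss of activity in these cells. Compound 1, with plain hydrogen there, keeps the lowest number of the four, and nothing available explains why methoxy raises the number.

Still open, as far as these compounds go, is whether a hydroxyl group or an amine on this same carbon would behave like methoxy or stay nearer to hydrogen. A longer chain such as ethoxy would show whether the loss grows with the size of the group.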